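Sulfur for Oxygen in the Linker of Compound 2

This account rests on a few compounds, and the source may have more. Where it says the series, first, only, none or still open, it means among the compounds named here.

The series shares one core, seen in compound 1 `Cn1ncc2c(=O)n(-c3ccccc3)c(CNc3cccc(F)c3)nc21`, compound 2 `Cn1ncc2c(=O)n(-c3ccccc3)c(COc3cccc(F)c3)nc21` and compound 3 `C[C@H](Sc1nc2c(cnn2C)c(=O)n1-c1ccccc1)c1ccccc1`. In an assay on isolated protein for inhibition of aldehyde dehydrogenase 1A1 (Homo sapiens) (on this read-out lower numbers stand for stronger inhibition and higher numbers for weaker inhibition), compound 1 gives 570 nM, compound 2 gives 8200 nM and compound 3 gives 1410 nM. Compound 2 thus stands at the highest number of the three, with compound 3 the nearer of the other two and compound 1 the further, both gaps beyond the scatter.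

Going by the values given here, the only single-point step among the measured compounds runs from compound 1 to compound 2 and gave a 14-fold higher number from compound 1 to compound 2 (1.16 log units; beyond the scatter), with 3-fluorophenoxy in place of (3-fluorophenyl)amino.

Compound 4 `Cn1ncc2c(=O)n(-c3ccccc3)c(CSc3cccc(F)c3)nc21` is not yet measured. It differs from compound 2 by (3-fluorophenyl)sulfanyl in place of 3-fluorophenoxy on a saturated chain carbon bound to an aromatic carbon. Among the compounds with values here, no measured step swaps oxygen for sulfur at this place, so the only bearing comes from the nearby compound 3, which carries a sulfur link on its own chain and sits at a lower number than compound 2. It is therefore expected that compound 4 gives a number below compound 2, with a 3.3-fold lower number from compound 2 to compound 4 (0.52 log units; beyond the scatter) as the estimated step, though the range is wide. For compound 4 the estimate in this assay is 2500 nM, between 800 nM and 8000 nM.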

Compound 4, half-maximal inhibitory concentration: 720 nM
Beside the measured number, compound 4's estimate is 3.5-fold (0.54 log units) above it; the measured number lies below the stated range.
By their numbers in this assay, from the lowest: compounds 1, 4 and 3 (each within the scatter of the next, the first and the last beyond it); then compound 2.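

In this assay, going by these compounds alone, the single earlier step at this place could not say whether the amino link of compound 1 was special or the oxygen link of compound 2 was poor, and the new result settles that for these three links: (3-fluorophenyl)sulfanyl in place of 3-fluorophenoxy gives an 11-fold lower number from compound 2 to compound 4 (1.06 log units; beyond the scatter), a large step. The same group in place of (3-fluorophenyl)amino gives a 1.3-fold higher number from compound 1 to compound 4 (0.10 log units; within the scatter), so a link without the amino nitrogen can match the amino link, and among compounds 1, 2 and 4 only the oxygen link of compound 2 stands apart. Nothing measured in this set accounts for why the oxygen link alone departs from the other two.

The compounds shown leave open whether a sulfoxide or sulfone at this place, a plain methylene link or a longer chain on the saturated carbon would stay with the sulfur and amino links or fall with the oxygen one. They also leave open whether the same pattern among the links would hold with the fluorine removed or with a chlorine in its stead.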